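A chloro group on the core of compound 1

The source may hold more compounds than are shown below. What is called first, only, known or untested is meant among the compounds shown, and "the series" means these compounds.

Measured so far in a functional assay on A549 cells (Homo sapiens) for cytotoxicity, read by MTT assay, with a stated time of 48 h; a lower number here means a stronger inhibitor, a higher number a weaker inhibitor
compound 1 `CCn1c(/C=C2/C(=O)Nc3ccccc32)nc2ccccc21` gives > 50000 nM (a limit of the assay, not a number)
compound 2 `CC(C)n1c(/C=C2/C(=O)Nc3ccc(F)cc32)nc2ccccc21` gives 28500 nM
compound 3 `Cn1c(/C=C2/C(=O)Nc3ccc(Br)cc32)nc2ccccc21` gives 41200 nM

Compound 1 has no number of its own (> 50000 nM), and this value is only a limit. Its place in the series is therefore open on one side.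

Compound 4 `CCn1c(/C=C2/C(=O)Nc3ccc(Cl)cc32)nc2ccccc21` is compound 1 with chloro in place of hydrogen on an aromatic carbon. For the measured compounds named here, no step between measured compounds gauges this change. The nearest guides are compound 2 (28500 nM), which carries a fluoro group, and compound 3 (41200 nM), which carries a bromo group. Both also differ from compound 1 in another group, yet both return numbers, and these lie within the scatter of each other.

A modest move toward stronger inhibition in this assay is therefore expected, an estimated at least 1.5-fold lower number from compound 1 to compound 4 (0.19 log units; that floor lies within the scatter) at most of moderate size, and the assay may again report only a limit. Compound 4 is estimated at 32000 nM (range 15000 nM to 60000 nM).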

Compound 4, half-maximal inhibitory concentration: > 50000 nM
Compound 4: a limit, no number; the forecaster's own chance of this, stated with the estimate: 30%; middle value at least 1.5-fold (0.19 log units) from the limit.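

In this assay, compound 1 and compound 4 both stand at a limit and not at a number, so no step can be read between them: the limit of > 50000 nM in this assay, at which 2 of the 4 values shown sit.

Going by these compounds, whether chloro in place of hydrogen on an aromatic carbon shifts the value at all, and in which direction, stays open.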